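The compounds below may be only part of what the source reports. "The series", "measured", "known", "first", "only" and "open" are said of these compounds alone.

Three measured compounds share one core and differ only in the substituents on the two aryl rings. Compound 1 `O=C(/C=C/c1ccc([N+](=O)[O-])cc1)Nc1cc(-c2ccccc2)[nH]n1` gives 970 nM in a functional assay on A549 cells (Homo sapiens) for antiproliferative activity, read by MTT assay, with a stated time of 48 h; a higher number here means a weaker inhibitor, a lower number a stronger inhibitor. Compound 2 `Cc1ccc(-c2cc(NC(=O)/C=C/c3ccc(Br)cc3)n[nH]2)cc1` gives 1590 nM, and compound 3 `O=C(/C=C/c1ccccc1)Nc1cc(-c2ccc(Br)cc2)[nH]n1` gives 1440 nM. Compound 1 has the lowest of the three numbers, but its gap to compound 3 and its gap to compound 2 both lie within the scatter of this assay, so no order among the three can be read from these values.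

Compound 4 `O=C(/C=C/c1ccc(Cl)cc1)Nc1cc(-c2ccccc2)[nH]n1` is not yet measured. It differs from compound 1 in one place: chloro in place of nitro on an aromatic carbon. Going by the values given here, no pair of measured compounds isolates this exact change, so its size is not known. Halogen substitution elsewhere on the aryl rings in compound 2 and compound 3 leaves the numbers within the scatter of compound 1, so the step from compound 1 to compound 4 is expected to be small, with no clear direction beyond the scatter: the expected step is a 1.3-fold higher number from compound 1 to compound 4 (0.13 log units; within the scatter). Compound 4 is estimated at 1300 nM in this assay, with a range of 500 nM to 3500 nM.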

Compound 4, half-maximal inhibitory concentration: 1390 nM
Compound 4: the middle estimate sits 1.1-fold (0.03 log units) below what was measured; low and high end bracket the measured number.
By their numbers in this assay, from the lowest: compounds 1, 4, 3 and 2 (each within the scatter of the next).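

Going by these compounds alone, on the aromatic carbon para to a large group, chloro in place of nitro gives a 1.4-fold higher number from compound 1 to compound 4 (0.16 log units; within the scatter) in this assay, the first direct reading of this change. For this pair, a nitro group with 3 heavy atoms and 2 hydrogen-bond acceptors can therefore give way to a chloro group with 1 heavy atom and no hydrogen-bond acceptors without a step beyond the scatter. No measured evidence bears on this result.

On these data alone, whether an amine, a carboxylic acid or a methoxy group at the same position would also stay within the scatter remains open. Also open, as far as these compounds go, is whether the chloro and nitro groups would read alike with bromo or methyl on the other aryl ring.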